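A swap of one group on an aromatic nitrogen

This account rests on a few compounds, and the source may have more. Where it says the series, first, only, none or still open, it means among the compounds named here.

In a functional assay on NCI-H69 cells (Homo sapiens) for cytotoxicity, read by MTT assay, with a stated time of 3 days (on this read-out higher numbers stand for weaker inhibition and lower numbers for stronger inhibition), compound 1 `C[C@H]1O[C@@H](n2cc(F)c(NC(=O)Oc3ccc(Cl)cc3)nc2=O)[C@H](O)[C@@H]1O` reads 90 ug/mL and compound 2 `C[C@H]1O[C@@H](n2cc(F)c(NC(=O)Oc3ccc([N+](=O)[O-])cc3)nc2=O)[C@@H]2OC(=O)O[C@@H]21` reads 30 ug/mL as the lower of the two numbers. Its gap to compound 1 lies beyond the scatter, so compound 2 stands as the stronger inhibitor of this pair.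

Compound 3 `C[C@H]1O[C@@H](n2cc(F)c(NC(=O)Oc3ccc([N+](=O)[O-])cc3)nc2=O)[C@H](O)[C@@H]1O` has no number yet. It departs from compound 2 in a single place: a group of 8 heavy atoms (5 carbon, 3 oxygen; one five-membered non-aromatic ring with 1 hetero atom) in place of a group of 10 heavy atoms (6 carbon, 4 oxygen; one five-membered non-aromatic ring with 1 hetero atom, one five-membered non-aromatic ring with 2 hetero atoms), on an aromatic nitrogen and the rest of the structure stays the same.

Among the compounds with values here, no measured pair isolates this change, so the data offer no direct step to lean on. Within the data shown here, the only guide is the span set by compound 1 at 90 ug/mL and compound 2 at 30 ug/mL and a value inside that span seems the most likely outcome. A modest move towards weaker inhibition is expected, an estimated step of a 1.7-fold higher number from compound 2 to compound 3 (0.22 log units; within the scatter) on the higher side of the starting number. In this assay the estimate for compound 3 is 50 ug/mL with an expected range of 18 ug/mL to 130 ug/mL until the measurement is in.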

Compound 3, half-maximal inhibitory concentration: 100 ug/mL
Compound 3: the middle estimate sits 2.0-fold (0.30 log units) below what was measured; the measured number falls inside the stated range.
By their numbers in this assay, from the lowest: compound 2; then compounds 1 and 3 (each within the scatter of the next).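

In this assay, within the data shown here, putting the 3,4-dihydroxy-5-methyloxolan-2-yl group on the aromatic nitrogen in place of the larger group of compound 2, with its two five-membered non-aromatic rings, gives a 3.3-fold higher number from compound 2 to compound 3 (0.52 log units; beyond the scatter), the first reading of a single change at this position, and it shows that the read-out responds to what the nitrogen carries. Nitro in place of chloro on an aromatic carbon gives a 1.1-fold higher number from compound 1 to compound 3 (0.05 log units; within the scatter), so with the 3,4-dihydroxy-5-methyloxolan-2-yl group on the nitrogen this swap does not separate the two compounds. Nothing at hand accounts for the step at the aromatic nitrogen.

From the compounds shown here alone, whether chloro and nitro would also read alike with the larger group of compound 2 on the nitrogen stays open, and so does which part of that larger group goes with the lower number. Also open, going by these compounds, is how the series would read with an amine or a carboxylic acid in place of nitro and chloro on the aromatic carbon, or with a simple alkyl chain on the aromatic nitrogen.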